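Swapping the aryl ring on a piperazine at the serotonin 7 receptor

This account rests on a few compounds, and the source may have more. Where it says the series, first, only, none or still open, it means among the compounds named here.

Compound 1 `O=C1c2ccccc2S(=O)(=O)N1CCCCCCN1CCN(c2ccccc2F)CC1`: 322 nM
Compound 2 `O=C1c2ccccc2S(=O)(=O)N1CCCCCCN1CCN(c2cccc(C(F)(F)F)c2)CC1`: 58 nM
Compound 3 `O=C1c2ccccc2S(=O)(=O)N1CCCCCCN1CCN(c2cccc3cccnc23)CC1`: 21 nM

Three compounds share one core and differ only in the aromatic ring attached to an amine nitrogen in a ring. In an ADME assay on HEK293 cells for displacement of a labelled ligand from 5-hydroxytryptamine receptor 7 (Homo sapiens), read by radioligand binding, with a stated time of 1 h (on this read-out lower numbers stand for stronger inhibition and higher numbers for weaker inhibition), compound 3 gives the lowest number of the three. The step of a 15-fold lower number from compound 1 to compound 3 (1.19 log units; beyond the scatter) was large, and the step of a 2.8-fold lower number from compound 2 to compound 3 (0.44 log units; beyond the scatter) was modest, so the choice of this aromatic ring clearly moves the result.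

Compound 4 `O=C1c2ccccc2S(=O)(=O)N1CCCCCCN1CCN(c2ncccn2)CC1` makes a further change at the same place: pyrimidin-2-yl in place of quinolin-8-yl on an amine nitrogen in a ring. Among the compounds with values here, none of the measured steps tests this particular ring, but all three show that the identity of the ring matters, with changes ranging from a 5.6-fold lower number from compound 1 to compound 2 (0.74 log units; beyond the scatter) to a 15-fold lower number from compound 1 to compound 3 (1.19 log units; beyond the scatter). Since the quinolin-8-yl of compound 3 gave the best result seen, and the entering ring is smaller and different in kind, compound 4 is expected to show a weaker result, a step of about a 7.1-fold higher number from compound 3 to compound 4 (0.85 log units; beyond the scatter). The estimate for compound 4 in this assay is 150 nM, within a range from 40 nM to 600 nM.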

Compound 4, inhibition constant: 35 nM
Compound 4: the middle estimate sits 4.3-fold (0.63 log units) above what was measured; measured number below the stated range.
By their numbers in this assay, from the lowest: compounds 3, 4 and 2 (each within the scatter of the next, the first and the last beyond it); then compound 1.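

The single ring of pyrimidin-2-yl serves this position on an amine nitrogen about as well as the two-ring quinolin-8-yl (a 1.7-fold higher number from compound 3 to compound 4 (0.22 log units; within the scatter)), so the second ring that leaves is not needed for a low number in this series. The pyrimidin-2-yl result also matches that of the 3-(trifluoromethyl)phenyl (a 1.7-fold lower number from compound 2 to compound 4 (0.22 log units; within the scatter)) and lies clearly under that of the 2-fluorophenyl (a 9.2-fold lower number from compound 1 to compound 4 (0.96 log units; beyond the scatter)), which shows that fewer heavy atoms in this group need not mean a weaker result. No measurement at hand explains these differences.

The compounds shown leave open how a pyridin-2-yl ring, with a single ring nitrogen, would compare with pyrimidin-2-yl. They also leave open whether these results would hold with a shorter chain joining the shared core to the piperazine.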